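Taking Away One Methyl Group on a Second Core

A few compounds are considered here, and "the series" means these few. Any claim that something is new, unique, unknown or untested is made for them only; others in the source may bear on it.

Compound 3 `Cc1cc(C)c2c(O)cc(-c3cccc(Cl)c3)nc2n1` is the most potent compound measured here in a functional assay on PC-3 cells (Homo sapiens) for antiproliferative activity (a lower number here means a stronger inhibitor of growth, a higher number a weaker inhibitor of growth), where compound 3 gives 27.5 nM. Compound 1 `Cc1ccc2c(O)cc(-c3cccc(Cl)c3)nc2n1` has the same shape except for one change: hydrogen in place of methyl on an aromatic carbon. In this assay compound 1 reaches only a limit of the assay, not a number, at > 100000 nM; this is the limit of > 100000 nM in this assay, at which 1 of the 3 values shown sits. The step of an at least 3600-fold higher number from compound 3 to compound 1 (3.56 log units; beyond the scatter) is therefore a large loss of growth inhibition, and its lower end is set by that limit rather than by a measured point.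

Compound 2 `Cc1cc(C)c2c(O)cc(-c3cccc4ccccc34)nc2n1` carries a different group on the shared core; the difference between the cores of compound 2 and compound 3 is not broken down here. In this assay compound 2 gives 759 nM, a higher number than compound 3 and beyond the usual scatter.

Compound 4 `Cc1ccc2c(O)cc(-c3cccc4ccccc34)nc2n1` has not yet been measured. It differs from compound 2 by hydrogen in place of methyl on an aromatic carbon. The place of this change is the same, word for word, as in the change from compound 3 to compound 1, so it is the same change made on a second core. Because the step of an at least 3600-fold higher number from compound 3 to compound 1 (3.56 log units; beyond the scatter) was so large, the step from compound 2 to compound 4 is expected to be a 130-fold higher number from compound 2 to compound 4 (2.12 log units; beyond the scatter). Compound 4 is therefore estimated at 100000 nM, with a considerable chance that this assay reports only a limit for it.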

Compound 4, concentration for 50% growth inhibition: 30.2 nM
Compound 4: middle estimate off by 3300-fold (3.52 log units), on the high side, outside the stated range (below it).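

In this assay the same change gave a 25-fold lower number from compound 2 to compound 4 (1.40 log units; beyond the scatter), which runs opposite to the earlier step on the other core, and the two steps differ by far more than the scatter of such measurements: the same change on two cores in this assay, an at least 3600-fold higher number (3.56 log units; beyond the scatter) from compound 3 to compound 1 and a 25-fold lower number (1.40 log units; beyond the scatter) from compound 2 to compound 4, at least 91000-fold (4.96 log units) apart, beyond the scatter of two such steps. On these data alone, compound 1 gives only a limit of the assay, > 100000 nM, so the earlier step has no measured end and its true size is unknown: the limit of > 100000 nM in this assay, at which 1 of the 4 values shown sits. Even so, the two pairs show that the result of replacing this methyl group with hydrogen on one core could not be carried over to the other core in this series, but they do not show why the outcomes part, and two cores give no general rule for a third.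

The compounds shown leave open how the methyl group and the hydrogen compare when other groups take the place of those carried by these two cores. As far as these compounds go, it also remains open what happens when that aromatic carbon carries an ethyl group, a chlorine atom or an amine, and whether any of these would follow either of the two opposite results.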